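Chloro in place of methyl on compound 3

The source may hold more compounds than are shown below. What is called first, only, known or untested is meant among the compounds shown, and "the series" means these compounds.

In an ADME assay on L929 cells (Mus musculus) for cytotoxicity, read by MTT assay, with a stated time of 72 h (a lower number here means a stronger inhibitor, a higher number a weaker inhibitor), compound 1 `CC(=O)c1ccc(/N=C2\C=C(OCc3cn(S(=O)(=O)c4ccc(C)cc4)nn3)C(=O)c3ccccc32)cc1` gives 10800 nM as its reading. Compound 2 `Cc1ccc(S(=O)(=O)n2cc(COC3=C/C(=N\c4ccc(Br)cc4)c4ccccc4C3=O)nn2)cc1` returns > 20000 nM as a limit only. Among the compounds with values here, compound 3 `Cc1ccc(/N=C2\C=C(OCc3cn(S(=O)(=O)c4ccc(C)cc4)nn3)C(=O)c3ccccc32)cc1` gives 17700 nM and so lies within the scatter of its one numerical neighbour, with a 1.6-fold higher number from compound 1 to compound 3 (0.21 log units; within the scatter) as the gap. Compound 4 `Cc1ccc(S(=O)(=O)n2cc(COC3=C/C(=N\c4ccc(Cl)cc4)c4ccccc4C3=O)nn2)cc1` has chloro in place of methyl on an aromatic carbon, para to a large group, a change counted as chloro in place of methyl on an aromatic carbon in the structures. The closest measured change, an at least 1.1-fold lower number from compound 2 to compound 3 (0.05 log units; that floor lies within the scatter) for methyl in place of bromo, has a floor within the scatter, and an at least 1.8-fold higher number from compound 1 to compound 2 (0.26 log units; that floor lies within the scatter) for bromo in place of acetyl does too. Hence the expected 1.0-fold lower number from compound 3 to compound 4 (0.02 log units; within the scatter) in this assay is a step within the scatter. Compound 4 is estimated at 17000 nM with an expected range from 9000 nM to 30000 nM on repeated measurement.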

Compound 4, half-maximal inhibitory concentration: > 20000 nM
Compound 4 ended at the assay's limit; the forecaster's own chance of this, stated with the estimate: 40%; middle value at least 1.1-fold (0.07 log units) from the limit.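

In this assay, the change from 4-methylphenyl to 4-chlorophenyl gives an at least 1.1-fold higher number from compound 3 to compound 4 (0.05 log units; that floor lies within the scatter), and the other readable step is an at least 1.8-fold higher number from compound 1 to compound 4 (0.26 log units; that floor lies within the scatter). Compound 4 now stands with compound 2 as a limit, so chloro, like bromo, gives no number to set against methyl or acetyl on this carbon, and the step between those two limits cannot be read. Both floors therefore stay open-ended: the limit of > 20000 nM in this assay, at which 2 of the 4 values shown sit.

Going by these compounds, how far compound 2 and compound 4 lie past that limit remains open. So does whether an amine or a carboxylic acid on this aromatic carbon would give a step beyond the scatter.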